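Dichlorophenyl for Aminophenyl on a Shared Enone Core

A few compounds are considered here, and "the series" means these few. Any claim that something is new, unique, unknown or untested is made for them only; others in the source may bear on it.

Measured compounds:
- Compound 1, `COc1cc(-c2cc(/C=C/C(=O)c3ccc(N)cc3)[nH]n2)cc(OC)c1OC`: -63%
- Compound 2, `COc1ccc(-c2cc(/C=C/C(=O)c3ccc(OC)c(OC)c3)[nH]n2)cc1`: -98%

In a functional assay on ACHN cells (Homo sapiens) for cytotoxicity, read by sulforhodamine B assay, with a stated time of 48 h, tested at 100 uM (on this read-out higher numbers stand for a weaker effect at the one concentration tested and lower numbers for a stronger effect), compound 1 gives -63%. Compound 1 stands highest of the two numbers recorded; its nearest neighbour, compound 2, gives -98%, a number lower by a margin beyond the scatter. Within the data shown here, the two compounds differ in more than one place, so no single step between them can be read off.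

Compound 3, `COc1cc(-c2cc(/C=C/C(=O)c3ccc(Cl)c(Cl)c3)[nH]n2)cc(OC)c1OC`, has not yet been measured. It differs from compound 1 in one place: 3,4-dichlorophenyl in place of 4-aminophenyl on a carbonyl carbon. Nothing in the measured pair isolates this change, so the expectation rests on the spread of the numbers seen so far. Compound 3 is estimated to come out with -80%, within -105% to -50%, which means an expected step of a number 17 percentage points lower from compound 1 to compound 3 (beyond the scatter) toward a lower number.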

Compound 3, a percentage reported as activity, at one concentration (the size of the read-out at that concentration, not a potency): 16%
Compound 3: middle estimate off by 96 percentage points, on the low side, outside the stated range (above it).
By their numbers in this assay, from the lowest: compound 2; then compound 1; then compound 3.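

In this assay, the group on the carbonyl carbon proves far from neutral: 3,4-dichlorophenyl in place of 4-aminophenyl gives a number 79 percentage points higher from compound 1 to compound 3 (beyond the scatter), a large move toward a weaker effect with the rest of the structure held constant. The sign of the read-out changes as well, since compound 1 gives -63% and compound 3 gives 16%. No measurement at hand accounts for this step.

The single change removes the amine and brings in two chlorine atoms, so the compounds shown cannot tell whether the departure of the amine or the arrival of the chlorines drives the step. A plain phenyl or a phenyl carrying a single chlorine at this position would separate the two, and a hydroxyl or a carboxylic acid on the ring remains an open question.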